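The compounds below may be only part of what the source reports. "The series", "measured", "known", "first", "only" and "open" are said of these compounds alone.

Compound 1 `COc1cccc(CNCCCNc2ccnc3cc(CCC(C)C)ccc23)c1O` and compound 2 `CCC(CC)c1ccc2c(NCCCNCc3cccc(OC)c3O)ccnc2c1` share one core and differ at a single aromatic carbon. In a physicochemical assay for solubility, with a stated time of 18 h, at pH 7.4 (on this read-out lower numbers stand for lower solubility and higher numbers for higher solubility), compound 1 gives 4200 nM, and compound 2 gives 4200 nM, so compound 2 stands level with compound 1, the step of no change at the digits printed from compound 1 to compound 2 (within the scatter) lying within the scatter. Compound 3 `COc1cccc(Oc2ccc3c(NCCCNCc4cccc(OC)c4O)ccnc3c2)c1` changes the same aromatic carbon: 3-methoxyphenoxy in place of pentan-3-yl on an aromatic carbon. Going by the values given here, the only measured step at this carbon, no change at the digits printed from compound 1 to compound 2 (within the scatter), exchanged pentan-3-yl for isopentyl and offers little guidance for 3-methoxyphenoxy entering there. A modest downward step a 2.1-fold lower number from compound 2 to compound 3 (0.32 log units; beyond the scatter) in this assay is nonetheless expected. Compound 3 is estimated at 2000 nM, between 600 nM and 6000 nM.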

Compound 3, solubility: 14500 nM
Compound 3: middle estimate off by 7.3-fold (0.86 log units), on the low side; the measured number lies above the stated range.
By their numbers in this assay, from the lowest: compounds 1 and 2 (each within the scatter of the next); then compound 3.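

In this assay isopentyl and pentan-3-yl had stood level at this aromatic carbon, but 3-methoxyphenoxy gives a 3.5-fold higher number from compound 2 to compound 3 (0.54 log units; beyond the scatter) and a 3.5-fold higher number from compound 1 to compound 3 (0.54 log units; beyond the scatter). The read-out at this position therefore does respond to the group placed there, and the same higher number appears against both open-chain groups. Nothing measured here bears on why the number rises. The compounds shown leave open whether the ring or the oxygen link of 3-methoxyphenoxy carries the step, and how an amine or a carboxylic acid would read at this carbon.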